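The source may report more compounds than this note shows. Statements on the series, on what has been measured and on what is new or still open speak of the compounds shown alone.

The compounds measured so far:
Compound 1, `Clc1ccc(-c2cc(-c3ccco3)nc(-c3cccs3)c2)o1`: > 50000 nM in a functional assay on HCT-15 cells (Homo sapiens) for cytotoxicity, in the presence of a further agent that is not named here; on this read-out lower numbers stand for stronger inhibition and higher numbers for weaker inhibition
Compound 2, `Clc1ccc(-c2cc(-c3cccs3)nc(-c3ccccc3Cl)c2)o1`: 6190 nM
Compound 3, `Clc1cccc(-c2cc(-c3ccc(Cl)o3)cc(-c3cccs3)n2)c1`: 15500 nM

Of these three, compound 1 gives only a limit in this assay, > 50000 nM, as recorded in the limit of > 50000 nM in this assay, at which 1 of the 3 values shown sits. Among the two numbers that are not limits, compound 3 stands highest, with compound 2 nearest at a lower number; that gap is a 2.5-fold higher number from compound 2 to compound 3 (0.40 log units; beyond the scatter).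

Compound 4, `Cc1ccc(-c2cc(-c3ccc(Cl)o3)cc(-c3cccs3)n2)cc1`, has not yet been measured. It differs from compound 3 in one place: 4-methylphenyl in place of 3-chlorophenyl on an aromatic carbon.

Among the measured compounds shown here, two measured steps touch the same position. Replacing furan-2-yl by an aryl group lowered the number, an at least 8.0-fold lower number from compound 1 to compound 2 (0.90 log units; beyond the scatter) and an at least 3.2-fold lower number from compound 1 to compound 3 (0.50 log units; beyond the scatter), while moving the chlorine on that aryl group gave a 2.5-fold higher number from compound 2 to compound 3 (0.40 log units; beyond the scatter). For the measured compounds named here, no measured step involves a methylphenyl group, so the effect of this exchange is open. Since compound 4 keeps an aryl group at this position, it is expected to stay near compound 3, with a step of about a 1.2-fold lower number from compound 3 to compound 4 (0.08 log units; within the scatter) that may fall within the scatter. Compound 4 is therefore estimated at 13000 nM, between 4000 nM and 40000 nM.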

Compound 4, half-maximal inhibitory concentration: 9890 nM
Estimate against measurement, compound 4: 1.3-fold (0.12 log units) above; the measured number falls inside the stated range.
By their numbers in this assay, from the lowest: compounds 2, 4 and 3 (each within the scatter of the next, the first and the last beyond it). At a limit, above all of these: compound 1.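

In this assay, 4-methylphenyl in place of 3-chlorophenyl gives a 1.6-fold lower number from compound 3 to compound 4 (0.20 log units; within the scatter), and 4-methylphenyl in place of 2-chlorophenyl gives a 1.6-fold higher number from compound 2 to compound 4 (0.20 log units; within the scatter), so on this carbon next to the ring nitrogen, a phenyl group without chlorine serves as well as the two chlorophenyl groups. The advantage of these aryl groups over furan-2-yl therefore also holds without chlorine on the aryl group, with an at least 5.0-fold lower number from compound 1 to compound 4 (0.70 log units; beyond the scatter). Compound 1 is recorded only as a limit, so this step has no exact size: the limit of > 50000 nM in this assay, at which 1 of the 4 values shown sits.

Because the substituent and its place on the phenyl group change together in these steps, the effect of each cannot be separated. As far as these compounds go, how an amine, a carboxylic acid or a longer chain on that phenyl group would affect the number remains open.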